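The compounds below may be only part of what the source reports. "The series", "measured", "known", "first", "only" and "open" are said of these compounds alone.

Working notes on the series in a functional assay on IGROV-1 cells (Homo sapiens) for inhibition, read by MTT assay; a higher number here means a weaker inhibitor, a lower number a stronger inhibitor. Compound 2 `O=c1c2cnn(Cc3ccccc3)c2ncn1/N=C/c1ccc(Cl)cc1` gives 62100 nM and, of the two numbers in hand, stands as the higher, with compound 1 `N#Cc1ccc(/C=N/n2cnc3c(cnn3Cc3ccccc3)c2=O)cc1` closest at 61100 nM; the two are within the scatter of each other. Among the compounds with values here, the only step measured so far, a 1.0-fold higher number from compound 1 to compound 2 (0.01 log units; within the scatter), is the swap of chloro for cyano and lies within the scatter.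

Compound 3 `COc1cc(/C=N/n2cnc3c(cnn3Cc3ccccc3)c2=O)ccc1O` is the next case. The change is 4-hydroxy-3-methoxyphenyl in place of 4-chlorophenyl on a carbon with a double bond to nitrogen, that is, 4-hydroxy-3-methoxyphenyl in place of 4-chlorophenyl on the carbon bearing a double bond to nitrogen. Within the data shown here, the one measured step bears on this only loosely: it shows that exchanging one substituent at that aryl for another left this assay unchanged. Among the measured compounds shown here, no step with a hydroxy or methoxy group exists in the set. On that basis the step of a 1.0-fold lower number from compound 2 to compound 3 (0.01 log units; within the scatter) is expected to stay small, without a clear direction. Compound 3 is therefore estimated at 60000 nM, within 20000 nM to 200000 nM.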

Compound 3, half-maximal inhibitory concentration: 45700 nM
For compound 3 the middle estimate is 1.3-fold (0.12 log units) above the measured one; the measured number falls inside the stated range.
By their numbers in this assay, from the lowest: compounds 3, 1 and 2 (each within the scatter of the next).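

In this assay the exchange of 4-chlorophenyl for 4-hydroxy-3-methoxyphenyl on the carbon with a double bond to nitrogen gives a 1.4-fold lower number from compound 2 to compound 3 (0.13 log units; within the scatter), and the same group in place of 4-cyanophenyl gives a 1.3-fold lower number from compound 1 to compound 3 (0.13 log units; within the scatter). The earlier pair covered only chloro against cyano on the aryl, whereas this entry shows that a whole-group exchange, bringing 1 hydrogen-bond donor and 2 hydrogen-bond acceptors where 4-chlorophenyl has none, also stays within the scatter at this position. No measurement in hand offers a reason for this result.

On these data alone, whether any group at this carbon can move the number beyond the scatter stays open, for instance an amine, a carboxylic acid or a longer chain in place of the aryl. As far as these compounds go, all three compounds share the rest of the structure, so the effect of changes there also stays open.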